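Hydrazone series on the shared core: hydroxyphenyl variations

The source may hold more compounds than are shown below. What is called first, only, known or untested is meant among the compounds shown, and "the series" means these compounds.

Measured so far:
compound 1 `O=C(CSc1nnc(-c2ccncc2)n1-c1ccccc1)N/N=C/c1ccccc1` — 18600 nM
compound 2 `O=C(CSc1nnc(-c2ccncc2)n1-c1ccccc1)N/N=C/c1ccccc1O` — 11300 nM

In a functional assay on HepG2 cells (Homo sapiens) for inhibition, read by MTT assay, with a stated time of 48 h (on this read-out lower numbers stand for stronger inhibition and higher numbers for weaker inhibition), compound 2 gives 11300 nM, the lowest of the two numbers; its nearest neighbour is compound 1 with 18600 nM, and the gap between them is within the scatter. Among the measured compounds shown here, the only measured step is a 1.6-fold lower number from compound 1 to compound 2 (0.22 log units; within the scatter), a hydroxy in place of hydrogen on an aromatic carbon, and it did not rise above the scatter.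

Compound 3 `O=C(CSc1nnc(-c2ccncc2)n1-c1ccccc1)N/N=C/c1ccc(O)c(O)c1` is not yet measured. It differs from compound 2 by 3,4-dihydroxyphenyl in place of 2-hydroxyphenyl on a carbon with a double bond to nitrogen. The change again adds hydroxy to the same aromatic ring, so the step from compound 1 to compound 2 is the only one that bears on it, and it was small. No step beyond the scatter is expected in this assay, with at most a slight lowering, giving a 1.4-fold lower number from compound 2 to compound 3 (0.15 log units; within the scatter). Compound 3 is therefore estimated at 8000 nM, with a range from 3000 nM to 25000 nM.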

Compound 3, half-maximal inhibitory concentration: 16900 nM
Compound 3: the middle estimate sits 2.1-fold (0.32 log units) below what was measured, within the range that was stated.
By their numbers in this assay, from the lowest: compounds 2, 3 and 1 (each within the scatter of the next).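

In this assay, 3,4-dihydroxyphenyl in place of 2-hydroxyphenyl on a carbon with a double bond to nitrogen gives a 1.5-fold higher number from compound 2 to compound 3 (0.17 log units; within the scatter) and 3,4-dihydroxyphenyl in place of phenyl at the same place gives a 1.1-fold lower number from compound 1 to compound 3 (0.04 log units; within the scatter) as the second step. With both steps inside the scatter, phenyl, 2-hydroxyphenyl and 3,4-dihydroxyphenyl cannot be told apart here, so adding hydroxy to this aromatic ring has not yet moved the number beyond the scatter in any of the three compounds. No measurement is at hand that accounts for this flat result.

On these data alone, it remains open whether an amine, a carboxylic acid or a methoxy group on this aromatic ring would give a step beyond the scatter. As far as these compounds go, it is also open whether replacing the aromatic ring with a longer alkyl chain would do so.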